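This account rests on a few compounds, and the source may have more. Where it says the series, first, only, none or still open, it means among the compounds named here.

Compound 1, `c1ccc(-c2cn3ccnc3c(-c3ccc4ncn(C5CCCCC5)c4c3)n2)cc1`: 38.2%
Compound 2, `COc1ccc(-c2cn3ccnc3c(-c3ccc4ncn(C5CCCCC5)c4c3)n2)cc1`: 89.2%

In a functional assay on M14 cells (Homo sapiens) for inhibition, read by sulforhodamine B assay, with a stated time of 48 h, tested at 10 uM (a lower number here means less inhibition, a higher number more inhibition at the concentration tested (going by the name of the read-out)), compound 2 holds the highest of the two numbers; the step of a number 51 percentage points higher from compound 1 to compound 2 (beyond the scatter) separates compound 1 from it. Compound 3, `O=Cc1ccc(-c2cn3ccnc3c(-c3ccc4ncn(C5CCCCC5)c4c3)n2)cc1`, differs from compound 2 by formyl in place of methoxy on an aromatic carbon. Among the measured compounds shown here, the one measured step, which put methoxy in place of hydrogen on that aromatic carbon, was large, a number 51 percentage points higher from compound 1 to compound 2 (beyond the scatter), so what sits there matters, but nothing measured compares formyl with methoxy. Compound 3 is therefore expected to land between the two measured values, a step of a number 29.2 percentage points lower from compound 2 to compound 3 (beyond the scatter). Compound 3 is estimated at 60%, within 30% to 90%.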

Compound 3, a percentage reported as inhibition, at one concentration (the size of the read-out at that concentration, not a potency): 23%
Compound 3: middle estimate off by 37 percentage points, on the high side, outside the stated range (below it).
By their numbers in this assay, from the lowest: compound 3; then compound 1; then compound 2.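

In this assay, formyl and methoxy on this aromatic carbon give very different results, with a number 66.2 percentage points lower from compound 2 to compound 3 (beyond the scatter) and, against plain hydrogen, a number 15.2 percentage points lower from compound 1 to compound 3 (beyond the scatter). Among these three compounds, this position therefore does not reward just any added group: methoxy raises the number, whereas formyl lowers it, although both groups have the same heavy-atom count. Nothing available explains this difference. As far as these compounds go, it remains open whether an amine or a carboxylic acid here would land nearer compound 2 or compound 3, and whether ethoxy, with its longer chain, would match methoxy.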